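The source may report more compounds than this note shows. Statements on the series, on what has been measured and on what is new or still open speak of the compounds shown alone.

Measured in a functional assay on DU-145 cells (Homo sapiens) for cytotoxicity, read by sulforhodamine B assay, with a stated time of 48 h; a lower number here means a stronger inhibitor, a higher number a weaker inhibitor:

- Compound 1 `C[C@H]1CC[C@@H]2[C@@H](OC(=O)[C@]23CC(c2ccc(Cl)cc2)=NO3)[C@]2(C)C(=O)C=C[C@@]12O`: 43000 nM
- Compound 2 `COc1cc(C2=NO[C@]3(C2)C(=O)O[C@@H]2[C@H]3CC[C@H](C)[C@]3(O)C=CC(=O)[C@@]23C)ccc1O`: 71000 nM

Among the measured compounds shown here, only these two compounds have numbers so far, so compound 2, at 71000 nM, can be placed against compound 1 alone. The two lie within the usual scatter of each other. For the measured compounds named here, the single measured step, a 1.7-fold higher number from compound 1 to compound 2 (0.22 log units; within the scatter), replaced 4-chlorophenyl with 4-hydroxy-3-methoxyphenyl on a carbon with a double bond to nitrogen.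

Compound 3 `C[C@H]1CC[C@@H]2[C@@H](OC(=O)[C@]23CC(c2ccccc2F)=NO3)[C@]2(C)C(=O)C=C[C@@]12O` keeps the shared core and changes that same carbon again, with 2-fluorophenyl in place of 4-hydroxy-3-methoxyphenyl on a carbon with a double bond to nitrogen. Going by the values given here, one step is thin evidence, and no fluorine-bearing compound has been measured yet. Among the compounds with values here, still, the only exchange seen at this carbon, a 1.7-fold higher number from compound 1 to compound 2 (0.22 log units; within the scatter), stayed within the scatter, so no step beyond the scatter is expected in this assay. The expected change is a 1.4-fold lower number from compound 2 to compound 3 (0.14 log units; within the scatter). For compound 3 the estimated value is 52000 nM, with an expected range from 22000 nM to 120000 nM.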

Compound 3, half-maximal inhibitory concentration: 24000 nM
Beside the measured number, compound 3's estimate is 2.2-fold (0.34 log units) above it; the measured number falls inside the stated range.
By their numbers in this assay, from the lowest: compounds 3, 1 and 2 (each within the scatter of the next, the first and the last beyond it).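

In this assay, among the compounds shown here, the aryl exchange on this carbon now gives a step beyond the scatter, though a modest one: replacing 4-hydroxy-3-methoxyphenyl with 2-fluorophenyl gives a 3.0-fold lower number from compound 2 to compound 3 (0.47 log units; beyond the scatter) and is the first exchange here to stand clear of the usual variation. Replacing 4-chlorophenyl with 2-fluorophenyl gives a 1.8-fold lower number from compound 1 to compound 3 (0.25 log units; within the scatter) and remains within the scatter, so these two halogen-bearing phenyl groups cannot be told apart, and compound 3 cannot be called the strongest of the three. Nothing available here explains why only the exchange from compound 2 to compound 3 clears the scatter.

This exchange removes the hydroxy and methoxy groups and adds a fluorine in one move, so the compounds shown cannot separate the contribution of each, and a plain phenyl group would be needed to help divide them. All three compounds carry a substituted phenyl ring on this carbon, which leaves open how this assay would respond to a group without that ring, such as a short alkyl chain, an amine or a carboxylic acid.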